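Replacing an Ester With a Hydrazide in Rat Paw Edema

A few compounds are considered here, and "the series" means these few. Any claim that something is new, unique, unknown or untested is made for them only; others in the source may bear on it.

For the measured compounds named here, compound 2 `CC(C)(C)OC(=O)C(=O)Nc1cccccc1=O` gives 82% in a functional assay on the whole organism (strain Sprague-Dawley CD) for inhibition, with Rattus norvegicus as the target, read by paw edema, at a dose of 100 mg/kg by the oral route (on this read-out higher numbers stand for a stronger effect at the one dose given and lower numbers for a weaker effect), the higher of the two numbers measured so far, though only within the scatter. Going by the values given here, its one measured neighbour, compound 1 `CC(C)OC(=O)C(=O)Nc1cccccc1=O`, gives 72% in this assay, and the step of a number 10 percentage points higher from compound 1 to compound 2 (within the scatter) is within the scatter. Compound 3 `NNC(=O)C(=O)Nc1cccccc1=O` differs from compound 2 by aminoamino in place of tert-butoxy on a carbonyl carbon. Among the compounds with values here, no measured step concerns a change of this kind, so the expectation is uncertain. A step of a number 17 percentage points lower from compound 2 to compound 3 (beyond the scatter) is expected in this assay. Compound 3 is estimated at 65%, in a range from 40% to 90%.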

Compound 3, a percentage reported as inhibition, in the whole organism at one dose (the size of the read-out at that dose, not a potency): 78%
For compound 3 the middle estimate is 13 percentage points below the measured one; the range from low to high includes it.
By their numbers in this assay, from the lowest: compounds 1, 3 and 2 (each within the scatter of the next).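

On a carbonyl carbon, aminoamino can take the place of either alkoxy group with no change beyond the scatter in this assay: there is a number 4 percentage points lower from compound 2 to compound 3 (within the scatter) and a number 6 percentage points higher from compound 1 to compound 3 (within the scatter) here. Where the earlier pair compared only tert-butoxy and isopropoxy, this result shows that the effect at this dose also holds when a group with 2 nitrogen atoms and no carbon enters at this place. Nothing measured here explains this result.

As far as these compounds go, whether an amine, a carboxylic acid or a longer chain on this carbonyl carbon would keep the effect remains open. With one dose, the three compounds also cannot be ranked by potency.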